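A Ring Replaces a Chain on a Weakly Active Scaffold

The source may hold more compounds than are shown below. What is called first, only, known or untested is meant among the compounds shown, and "the series" means these compounds.

Compound 1 `CCCCn1c(Cc2cc(OC)c(OC)c(OC)c2)nc2c(N)nc(F)nc21` and compound 2 `CCCCn1c(Cc2c(Br)c(OC)c(OC)c(OC)c2Br)nc2c(N)ncnc21` share a core and were both tested in a functional assay on MCF7 cells (Homo sapiens) for antiproliferative activity; on this read-out higher numbers stand for weaker inhibition and lower numbers for stronger inhibition. In this assay compound 1 gives 24000 nM, and compound 2 gives 30200 nM; the two numbers lie within the scatter of each other, so neither stands apart. Compound 3 `COc1cc(Cc2nc3c(N)nc(F)nc3n2CC2CCCO2)cc(OC)c1OC` differs from compound 1 by the change (oxolan-2-yl in place of propyl on a saturated chain carbon bound to an aromatic nitrogen). Among the compounds with values here, no measured pair shows what this change does here. Because compound 1 gives 24000 nM, compound 3 is expected to stay close to it, with a step of a 1.2-fold lower number from compound 1 to compound 3 (0.08 log units; within the scatter) that should not go beyond the scatter. The estimate for compound 3 is 20000 nM, from 6000 nM to 70000 nM.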

Compound 3, half-maximal inhibitory concentration: 22900 nM
Beside the measured number, compound 3's estimate is 1.1-fold (0.06 log units) below it; the range from low to high includes it.
By their numbers in this assay, from the lowest: compounds 3, 1 and 2 (each within the scatter of the next).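

In this assay, the swap of butyl for (oxolan-2-yl)methyl gives a 1.0-fold lower number from compound 1 to compound 3 (0.02 log units; within the scatter), so the two numbers cannot be told apart. Compound 1 and compound 2 both carry butyl, so only compound 3 shows that this position accepts a ring with a hydrogen-bond acceptor and keeps its number within the scatter. Nothing measured here explains this result. Going by these compounds, what an amine or a carboxylic acid on the same saturated chain carbon would do remains open, as does whether any group there can move the number beyond the scatter.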